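Methoxy to trifluoromethoxy: the step to compound 4

The source may report more compounds than this note shows. Statements on the series, on what has been measured and on what is new or still open speak of the compounds shown alone.

Compounds measured in a functional assay on G-361 cells (Homo sapiens) for antiproliferative activity, with a stated time of 72 h; a higher number here means a weaker inhibitor, a lower number a stronger inhibitor:
Compound 1 `OC[C@H]1O[C@@H](n2cnc3c(NCc4cccc(F)c4)ncnc32)[C@H](O)[C@@H]1O`: > 166000 nM, a limit
Compound 2 `OC[C@H]1O[C@@H](n2cnc3c(NCc4ccccc4Cl)ncnc32)[C@H](O)[C@@H]1O`: "not determined" (no result reported)
Compound 3 `COc1ccccc1CNc1ncnc2c1ncn2[C@@H]1O[C@H](CO)[C@@H](O)[C@H]1O`: > 166000 nM, a limit

Compound 3 has no number, only a limit, > 166000 nM. It shares that position with compound 1, and neither can be ranked against the other. The picture so far is the limit of > 166000 nM in this assay, at which 2 of the 3 values shown sit. Compound 2 adds nothing, since no result was reported for it.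

Compound 4 `OC[C@H]1O[C@@H](n2cnc3c(NCc4ccccc4OC(F)(F)F)ncnc32)[C@H](O)[C@@H]1O` is the next step from compound 3, a change of methoxy to trifluoromethoxy: trifluoromethyl in place of methyl on an oxygen on an aromatic ring. Within the data shown here, only one measured step bears on it, a step that the two limits leave unreadable from compound 1 to compound 3. Among the measured compounds shown here, that step changes the same aromatic group, but it gives no size to carry over, and no measured step tests this exchange directly.

The expectation therefore rests on compound 3, whose value of > 166000 nM is a limit. No step beyond the usual scatter is expected, in either direction, and a result reported only as a limit is the likeliest outcome. In this assay the estimated move is a number no higher from compound 3 to compound 4 (the limit leaves the size open). For compound 4 the expected value is 166000 nM, with an estimated range of 60000 nM to 300000 nM.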

Compound 4, half-maximal inhibitory concentration: > 166000 nM
Compound 4: a limit, no number; the forecaster's own chance of this, stated with the estimate: 80%; the middle value lies on the limit itself.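

In this assay compound 4 gives > 166000 nM, a limit and not a number. Compound 3 also stands only as a limit, so no step can be read between compound 3 and compound 4. The series shows one recurring result: the limit of > 166000 nM in this assay, at which 3 of the 4 values shown sit.

The compounds shown leave open whether any member reaches a measurable value in this assay, and how their aromatic groups would rank.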